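Three Aryl Ethers at the Limit, and a Trifluorophenyl Variant

The compounds below may be only part of what the source reports. "The series", "measured", "known", "first", "only" and "open" are said of these compounds alone.

The shared core of this small set is a dipeptide-like chain that ends in an aromatic ether, and each member was tested in a functional assay on Jurkat cells (Homo sapiens); a lower number here means a stronger inhibitor, a higher number a weaker inhibitor. Compound 1 `CC(C)[C@H](NC(=O)COc1cccc2ccccc12)C(=O)N[C@@H](CC(=O)O)C(=O)COc1cccc(C(F)(F)F)c1` gives > 100000 nM, which is a limit of the assay and not a number. Compound 2 `CC(=O)Nc1cccc(OCC(=O)[C@H](CC(=O)O)NC(=O)[C@@H](NC(=O)COc2cccc3ccccc23)C(C)C)c1`, with acetamido in place of trifluoromethyl on an aromatic carbon, gives > 100000 nM, again only a limit. Compound 3 `CC(C)[C@H](NC(=O)COc1cccc2ccccc12)C(=O)N[C@@H](CC(=O)O)C(=O)COc1ccc([N+](=O)[O-])cc1`, with 4-nitrophenyl in place of 3-(trifluoromethyl)phenyl on an oxygen on a saturated carbon, gives > 100000 nM, once more a limit. Because of the limit of > 100000 nM in this assay, at which 3 of the 3 values shown sit, the steps a step that the two limits leave unreadable from compound 1 to compound 2, a step that the two limits leave unreadable from compound 1 to compound 3 and a step that the two limits leave unreadable from compound 2 to compound 3 cannot be sized at all.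

Compound 4 `CC(C)[C@H](NC(=O)COc1cccc2ccccc12)C(=O)N[C@@H](CC(=O)O)C(=O)COc1ccc(F)c(F)c1F` differs from compound 1 as follows: 2,3,4-trifluorophenyl in place of 3-(trifluoromethyl)phenyl on an oxygen on a saturated carbon. Within the data shown here, no measured step reads on this change, since every comparison so far sits at the limit. With all three comparison compounds at the limit, compound 4 is expected to sit there too, and the step that the limit leaves unreadable from compound 1 to compound 4 is therefore an expectation of no readable change. The estimate for compound 4 in this assay is 150000 nM, with a range from 40000 nM to 600000 nM.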

Compound 4, half-maximal inhibitory concentration: 35800 nM
The estimate for compound 4 lay 4.2-fold (0.62 log units) above the measured number; measured number outside the range, below it.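

In this assay, among these compounds, compound 4 is the only member of this set with a value that is a number and not a limit, so the group on this oxygen on a saturated carbon can move the read-out into the measurable range. Placing 2,3,4-trifluorophenyl here gives an at least 2.7-fold lower number from compound 1 to compound 4 (0.44 log units; beyond the scatter), an at least 2.7-fold lower number from compound 2 to compound 4 (0.44 log units; beyond the scatter) and an at least 2.7-fold lower number from compound 3 to compound 4 (0.44 log units; beyond the scatter), so it separates from 3-(trifluoromethyl)phenyl, 3-acetamidophenyl and 4-nitrophenyl alike. These sizes are only minimums, and the steps among compound 1, compound 2 and compound 3 cannot be read at all, because each of those compounds stands at a limit: the limit of > 100000 nM in this assay, at which 3 of the 4 values shown sit.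

Telling whether all three fluorines are needed, or whether one alone carries the change, would take a plain phenyl or a 4-fluorophenyl group on this oxygen. On these data alone, it also remains open whether 2,3,4-trifluorophenyl would keep this effect with a change elsewhere in the shared core, such as a methyl ester in place of the carboxylic acid.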